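Varying the Aryl Amide Group in Two Close Analogues

This account rests on a few compounds, and the source may have more. Where it says the series, first, only, none or still open, it means among the compounds named here.

For the measured compounds named here, compound 2 `COc1ccc(C(=O)Nc2cccc(-c3oc4cc(-c5ccc(F)cc5)ccc4c(=O)c3O)c2)c(F)c1` is one of two compounds measured in a functional assay on MCF7 cells (Homo sapiens) for antiproliferative activity, read by CCK-8 assay, with a stated time of 72 h; a lower number here means a stronger inhibitor, a higher number a weaker inhibitor. In this assay compound 2 gives 20000 nM, the highest of the two numbers shown, yet its only neighbour, compound 1 `COc1cccc(C(=O)Nc2cccc(-c3oc4cc(-c5ccc(F)cc5)ccc4c(=O)c3O)c2)c1`, lies within the scatter of it: compound 1 gives 15300 nM. Going by the values given here, the single measured step, a 1.3-fold higher number from compound 1 to compound 2 (0.12 log units; within the scatter), exchanges the aryl group on the carbonyl carbon and leaves the number unchanged beyond the scatter. Compound 3 `COc1cc(OC)cc(C(=O)Nc2cccc(-c3oc4cc(-c5ccc(F)cc5)ccc4c(=O)c3O)c2)c1` continues the same line of change: 3,5-dimethoxyphenyl in place of 2-fluoro-4-methoxyphenyl on a carbonyl carbon. Because the comparable exchange a 1.3-fold higher number from compound 1 to compound 2 (0.12 log units; within the scatter) stayed within the scatter, the step of a 1.2-fold lower number from compound 2 to compound 3 (0.07 log units; within the scatter) is expected to be small as well, with no direction claimed beyond the scatter. The estimate for compound 3 in this assay is 17000 nM, with a range from 6000 nM to 45000 nM.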

Compound 3, half-maximal inhibitory concentration: 3470 nM
For compound 3 the middle estimate is 4.9-fold (0.69 log units) above the measured one; the whole stated range lies above it.
By their numbers in this assay, from the lowest: compound 3; then compounds 1 and 2 (each within the scatter of the next).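

The aryl group on the carbonyl carbon is not as silent in this assay as the first step suggested: 3,5-dimethoxyphenyl in place of 2-fluoro-4-methoxyphenyl gives a clear change (a 5.8-fold lower number from compound 2 to compound 3 (0.76 log units; beyond the scatter)), and methoxy in place of hydrogen on an aromatic carbon gives another (a 4.4-fold lower number from compound 1 to compound 3 (0.64 log units; beyond the scatter)). Compound 3 thus stands lowest of the three, with its steps to both others beyond the scatter, and a single added methoxy is all that separates it from compound 1. Nothing given here explains why these changes lower the number.

The compounds shown leave open whether an amine, a carboxylic acid or a longer alkoxy chain in place of methoxy on this aryl group would lower the number further. As far as these compounds go, it also remains open whether the added methoxy would give a similar step on cells other than MCF7.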